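A few compounds are considered here, and "the series" means these few. Any claim that something is new, unique, unknown or untested is made for them only; others in the source may bear on it.

Measured so far:
compound 1 `CC(C)(N)C(=O)N[C@H](COCc1ccccc1)c1nnnn1Cc1ccc(NS(C)(=O)=O)cc1` — 259 nM in a functional assay on H4 cells for agonist activity at growth hormone secretagogue receptor type 1 (Homo sapiens), read by FLIPR; a lower number here means that less compound is needed, a higher number that more compound is needed for the effect
compound 2 `CC(C)(N)C(=O)N[C@H](COCc1ccccc1)c1nnnn1CCC#N` — 30 nM in this assay

Within the data shown here, compound 2 stands at the lowest of the two numbers; the only neighbour is compound 1, with the step of an 8.6-fold lower number from compound 1 to compound 2 (0.94 log units; beyond the scatter), which is beyond the scatter. That step exchanged the group on the saturated chain carbon bound to the aromatic nitrogen, replacing a substituted aromatic ring by a small nitrile-bearing chain.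

Compound 3 `CC(C)(N)C(=O)N[C@H](COCc1ccccc1)c1nnnn1CCC(=O)NCc1ccccc1` is not yet measured in this assay. It differs from compound 2 by benzylcarbamoyl in place of cyano on a saturated chain carbon, two bonds along the chain from an aromatic nitrogen. This is in part a reversal of the direction taken from compound 1 to compound 2: a small nitrile group gives way to a larger group that again carries an aromatic ring, an amide and a hydrogen-bond donor, though placed one chain atom further from the aromatic nitrogen and without the sulfonamide of compound 1. Among the measured compounds shown here, only the step of an 8.6-fold lower number from compound 1 to compound 2 (0.94 log units; beyond the scatter) bears on it, and it was a different exchange, so it sets a size but not a firm direction. A number somewhat higher than that of compound 2 is expected, with the step of a 3.0-fold higher number from compound 2 to compound 3 (0.48 log units; beyond the scatter) estimated to stay modest. For compound 3 the estimate in this assay is 90 nM, within 30 nM to 350 nM.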

Compound 3, half-maximal effective concentration: 51 nM
For compound 3 the middle estimate is 1.8-fold (0.25 log units) above the measured one, within the range that was stated.
By their numbers in this assay, from the lowest: compounds 2 and 3 (each within the scatter of the next); then compound 1.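

In this assay, the saturated chain carbon two bonds along the chain from the aromatic nitrogen accepts benzylcarbamoyl in place of cyano with a 1.7-fold higher number from compound 2 to compound 3 (0.23 log units; within the scatter), so 10 heavy atoms and a six-membered aromatic ring enter where 2 heavy atoms stood without a step that can be told from the scatter. An aromatic ring in the substituent is thus not enough on its own to bring the number up to that of compound 1, since a 5.1-fold lower number from compound 1 to compound 3 (0.71 log units; beyond the scatter) also stays beyond the scatter even though compound 3 carries such a ring. No measurement is available that would explain why cyano and benzylcarbamoyl read alike here.

The compounds shown leave open how a carboxylic acid or a primary amine in place of cyano on this chain carbon would read, and whether a longer chain carrying benzylcarbamoyl would stay level with compounds 2 and 3. Also open, as far as these compounds go, is whether a methanesulfonamido group on the benzene ring of benzylcarbamoyl would move the number towards that of compound 1.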